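Cyclohexyl in Place of Isopropyl at the Amine-Bearing Carbon

A few compounds are considered here, and "the series" means these few. Any claim that something is new, unique, unknown or untested is made for them only; others in the source may bear on it.

Of the compounds shown here, two have been measured in an assay on HEK293 cells for binding affinity to Gonadotropin-releasing hormone receptor (Homo sapiens), read by radioligand binding; a lower number here means a stronger inhibitor, a higher number a weaker inhibitor. Compound 1 `COc1cccc(-c2c(C)n(Cc3c(F)cccc3F)c(=O)n(C[C@@H](N)C3CCCC3)c2=O)c1F` gives 94 nM, and compound 2 `COc1cccc(-c2c(C)n(Cc3c(F)cccc3F)c(=O)n(C[C@@H](N)C(C)C)c2=O)c1F` gives 973 nM. Compound 2 thus stands at the weaker end of the two: the step of a 10-fold higher number from compound 1 to compound 2 (1.01 log units; beyond the scatter) shows that replacing the cyclopentyl ring with an isopropyl group cost a great deal of affinity.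

Compound 3 `COc1cccc(-c2c(C)n(Cc3c(F)cccc3F)c(=O)n(C[C@H](N)C3CCCCC3)c2=O)c1F` has not been measured. It differs from compound 2 by amino(cyclohexyl)methyl in place of 1-amino-2-methylpropyl on a saturated chain carbon bound to an aromatic nitrogen. Among the measured compounds shown here, the only step that bears on this change is the one from compound 1 to compound 2, which was large; compound 3 restores a saturated carbocycle at that carbon, now with six members instead of five. For the measured compounds named here, on that basis a gain in affinity is expected in this assay, though the stereocentre in compound 3 is drawn with the opposite configuration to that in compound 1 and compound 2, and no measured compound tells what that costs.

Compound 3 is therefore expected to reach about 250 nM, within 60 nM to 1200 nM, an expected step of a 3.9-fold lower number from compound 2 to compound 3 (0.59 log units; beyond the scatter).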

Compound 3, inhibition constant: 6.5 nM
Compound 3: middle estimate off by 38-fold (1.59 log units), on the high side; the measured number lies below the stated range.
By their numbers in this assay, from the lowest: compound 3; then compound 1; then compound 2.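

In this assay, amino(cyclohexyl)methyl does far more than recover what the isopropyl-bearing compound gave up, with a 150-fold lower number from compound 2 to compound 3 (2.18 log units; beyond the scatter), and it also goes beyond the cyclopentyl-bearing compound, with a 14-fold lower number from compound 1 to compound 3 (1.16 log units; beyond the scatter). The earlier pair showed only that a carbocycle at this carbon outdid an open isopropyl group; this result shows that the numbers also separate one saturated carbocycle from another, and that the stereocentre drawn the opposite way in compound 3 did not prevent the lowest number of the three. Nothing available here accounts for the size of these steps.

Ring size and drawn configuration both differ between compound 1 and compound 3, so the compounds shown leave open how much of that step belongs to the six-membered ring and how much to the stereocentre. They also leave open whether the trend in ring size continues to a cycloheptyl ring, or whether a phenyl or piperidine ring on the same amine-bearing carbon would hold the affinity of compound 3.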